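A few compounds are considered here, and "the series" means these few. Any claim that something is new, unique, unknown or untested is made for them only; others in the source may bear on it.

Compound 1 `Cc1ccc2ccc(-c3cccc(OC(F)(F)F)c3)cc2n1`: in a functional assay on CHO cells for inhibition of metabotropic glutamate receptor 5 (Rattus norvegicus), read by FLIPR and calcium flux (on this read-out lower numbers stand for stronger inhibition and higher numbers for weaker inhibition), compound 1 reaches only the limit > 10000 nM, which is not a number.
Compound 2 `Cc1ccc2ccc(-c3cc(Cl)cc(C#N)c3)cc2n1`: in this assay compound 2 gives 1.4 nM.

Among the compounds with values here, compound 2 therefore holds the only number in hand; the one further value is a limit, (the limit of > 10000 nM in this assay, at which 1 of the 2 values shown sits). Compound 3 `Cc1ccc2ccc(-c3cc(C#N)cc(OCC(C)C)c3)cc2n1` differs from compound 2 at a single site: isobutoxy in place of chloro on an aromatic carbon. Within the data shown here, no step between two measured compounds is available to set the size of such a change, so the expectation rests on the two values alone. Compound 2, carrying chloro and a cyano group, gives 1.4 nM. Compound 1, carrying trifluoromethoxy and no cyano group, sits at a limit only. The cyano group is kept in compound 3, and the isobutoxy brings more heavy atoms and one acceptor where chloro brought none. The expected step is an 11-fold higher number from compound 2 to compound 3 (1.03 log units; beyond the scatter) towards weaker inhibition. Compound 3 is estimated at 15 nM, within 2 nM to 150 nM.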

Compound 3, half-maximal inhibitory concentration: 12000 nM
Compound 3: the middle estimate sits 800-fold (2.90 log units) below what was measured; the measured number lies above the stated range.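

In this assay, isobutoxy in place of chloro on an aromatic carbon, meta to a cyano group, gives an 8600-fold higher number from compound 2 to compound 3 (3.93 log units; beyond the scatter). Compound 2 and compound 3 both carry the cyano group, which shows that the cyano group alone does not secure strong inhibition and that the group at this one site makes a large difference within this pair. Compound 1 remains a limit and not a number, it differs from compound 3 in more than one place, and steps to it cannot be read: the limit of > 10000 nM in this assay, at which 1 of the 3 values shown sits.

As far as these compounds go, whether methoxy, bromo or an ethoxy chain at this site would keep the low number of compound 2 or share the high number of compound 3 remains open. Within the data shown here, the single pair also does not separate the part played by the oxygen, the branched chain and the departure of chloro.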